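A few compounds are considered here, and "the series" means these few. Any claim that something is new, unique, unknown or untested is made for them only; others in the source may bear on it.

Measured so far:
Compound 1 `CCOC(=O)/C(C#N)=C(/Nc1ccc([N+](=O)[O-])cc1)N[C@H](C)c1ccccc1` gives 23.6% in a functional assay on A-431 cells (Homo sapiens) for antiproliferative activity, read by MTT assay, with a stated time of 72 h, tested at 5 uM; on this read-out higher numbers stand for more inhibition at the one concentration tested (going by the name of the read-out) and lower numbers for less inhibition.
Compound 2 `CCOC(=O)/C(C#N)=C(/Nc1ccc(Br)cc1)N[C@H](C)c1ccccc1` gives 16.1% in this assay.

Compound 1 holds the higher of the two numbers, with compound 2 nearest; the step of a number 7.5 percentage points lower from compound 1 to compound 2 (within the scatter) is within the scatter. Compound 3 `CCOC(=O)/C(C#N)=C(/Nc1ccc([N+](=O)[O-])cc1)N[C@@H](C)c1ccccc1` is reached from compound 1 by the two compounds have the same atoms and bonds and differ only in configuration as drawn: 1 of 2 stereo elements differ; a stereocentre at a saturated chain carbon is drawn R in compound 1 and S in compound 3. Within the data shown here, no measured step concerns a change of configuration; the single step available, a number 7.5 percentage points lower from compound 1 to compound 2 (within the scatter), is a substituent swap and sits within the scatter, so it gives no direction for compound 3. No step beyond the scatter is therefore expected in this assay. Compound 3 is estimated at 22%, range 8% to 38%, which means an expected step of a number 1.6 percentage points lower from compound 1 to compound 3 (within the scatter).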

Compound 3, a percentage reported as inhibition, at one concentration (the size of the read-out at that concentration, not a potency): 18.1%
The estimate for compound 3 lay 3.9 percentage points above the measured number, within the range that was stated.
By their numbers in this assay, from the lowest: compounds 2, 3 and 1 (each within the scatter of the next).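

The pair isolates configuration at the stereocentre at a saturated chain carbon, which the earlier bromo-for-nitro swap did not address: the fact that compounds 1 and 3 differ only in the configuration as drawn. In this assay, the result is a number 5.5 percentage points lower from compound 1 to compound 3 (within the scatter), so the R and S drawings are not separated at the one concentration tested. This reading applies only to the nitro compounds.

On these data alone, whether the bromo compound behaves the same way with its stereocentre drawn S remains open. Also open, as far as these compounds go, is what an amine in place of the nitro, or a longer chain at the stereocentre, would give.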